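Swapping Dimethylamino for Methyl on Two Related Cores

A few compounds are considered here, and "the series" means these few. Any claim that something is new, unique, unknown or untested is made for them only; others in the source may bear on it.

Four compounds share a common framework in which a six-membered aromatic ring of carbon only is joined through a double bond to a larger core. Compound 1 `Cc1ccc(/C=C2\S/C(=N\c3csc(-c4ccc(Cl)cc4)c3)NC2=O)cc1` carries a methyl on that ring, and compound 2 `CN(C)c1ccc(/C=C2\S/C(=N\c3csc(-c4ccc(Cl)cc4)c3)NC2=O)cc1` carries a dimethylamino at the same place. In a functional assay on MCF7 cells (Homo sapiens) for cytotoxicity, read by MTT assay, with a stated time of 72 h (a lower number here means a stronger inhibitor, a higher number a weaker inhibitor), compound 1 gives 900 nM, and compound 2 gives 400 nM. The step of a 2.3-fold higher number from compound 2 to compound 1 (0.35 log units; beyond the scatter) goes with the change (methyl in place of dimethylamino on an aromatic carbon).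

Compound 3 `CN(C)c1ccc(/C=C2\S/C(=N\c3nc(-c4ccc(Cl)cc4)cs3)NC2=O)cc1` keeps the dimethylamino group but differs from compound 2 in its core; the difference between the two cores is not broken down here. In this assay compound 3 gives 100 nM, the lowest of the three numbers, beyond the scatter from both others.

Compound 4 `Cc1ccc(/C=C2\S/C(=N\c3nc(-c4ccc(Cl)cc4)cs3)NC2=O)cc1` has not yet been measured. It differs from compound 3 by methyl in place of dimethylamino on an aromatic carbon, the same change that separates compound 2 from compound 1, at the same kind of place. Among the compounds with values here, whether this change behaves the same way on the second core cannot be known from three measurements, so the earlier step is the only guide. Compound 4 is therefore expected to show a similar step, a 2.3-fold higher number from compound 3 to compound 4 (0.36 log units; beyond the scatter), resting on the earlier step of a 2.3-fold higher number from compound 2 to compound 1 (0.35 log units; beyond the scatter). For compound 4 in this assay the estimated value is 230 nM, with a likely range from 120 nM to 500 nM.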

Compound 4, half-maximal inhibitory concentration: 400 nM
The estimate for compound 4 lay 1.7-fold (0.24 log units) below the measured number, and the stated range covers the measured number.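

In this assay, putting methyl in place of dimethylamino on the second core gives a 4.0-fold higher number from compound 3 to compound 4 (0.60 log units; beyond the scatter), a step in the same direction as the one seen on the first core, so both pairs lose strength with this swap. Within the data shown here, the two steps agree as closely as measurements of this kind can show, and the larger-looking number on the second core should not be read as a real difference between the cores: the same change on two cores in this assay, a 2.3-fold higher number (0.35 log units; beyond the scatter) from compound 2 to compound 1 and a 4.0-fold higher number (0.60 log units; beyond the scatter) from compound 3 to compound 4, 1.8-fold (0.25 log units) apart, within the scatter of two such steps This supports carrying the change from one of these two cores to the other as a fair working guide, but it rests on only two pairs in a single cell assay, so it shows neither that the step would hold on a third core nor why the swap moves the number at all.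

The compounds shown compare only dimethylamino and methyl on this ring, so it stays open how a methoxy group, a primary amine, a carboxylic acid or a longer alkyl chain would behave at the same place. Going by these compounds, it also stays open whether a step of this size would appear on either core with those groups, or in cells other than the ones used here.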